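Phenyl in Place of Thiophen-3-yl: Expecting Another Limit

The compounds below may be only part of what the source reports. "The series", "measured", "known", "first", "only" and "open" are said of these compounds alone.

Of the compounds shown here, two have been tested in a functional assay on HepG2 cells (Homo sapiens) for antiproliferative activity, read by XTT assay, with a stated time of 72 h; on this read-out higher numbers stand for weaker inhibition and lower numbers for stronger inhibition. Compound 1 `Nc1nc(N)c2c(-c3ccsc3)cn([C@@H]3O[C@H](CO)[C@@H](O)[C@H]3O)c2n1` carries a thiophen-3-yl group on its core. In this assay compound 1 gives > 20000 nM, which is a limit of the assay rather than a number. Compound 2 `Cc1ncnc2c1c(-c1cc3ccccc3o1)cn2[C@@H]1O[C@H](CO)[C@@H](O)[C@H]1O` is built on a related core with a different aromatic group. In this assay compound 2 gives > 20000 nM, again a limit. Compound 1 therefore stands at the limit, where both values sit (the limit of > 20000 nM in this assay, at which 2 of the 2 values shown sit). Within the data shown here, no measured step between compounds 1 and 2 is set out, as they differ in more than one place; their two values show only that neither reaches a measurable number.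

Compound 3 `Nc1nc(N)c2c(-c3ccccc3)cn([C@@H]3O[C@H](CO)[C@@H](O)[C@H]3O)c2n1` is the untested partner of compound 1: phenyl in place of thiophen-3-yl on an aromatic carbon. Among the measured compounds shown here, with no measured step to lean on, the expectation is that this change moves the read-out by nothing beyond the usual scatter, so the step from compound 1 to compound 3 is estimated as a step that the limit leaves unreadable from compound 1 to compound 3. Compound 3 is expected to give 30000 nM, within a range from 10000 nM to 100000 nM, and most likely as another limit rather than a number.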

Compound 3, half-maximal inhibitory concentration: > 20000 nM
Compound 3: no number, only a limit; the forecaster's own chance of this, stated with the estimate: 80%; the middle value is on the limit's open side.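

In this assay compound 3 gives > 20000 nM, a limit of the assay and not a number. Compound 1 also sits at a limit, so no step from compound 1 to compound 3 can be read: the limit of > 20000 nM in this assay, at which 3 of the 3 values shown sit.

The compounds shown leave open whether phenyl and thiophen-3-yl differ at all on the shared core, and whether any related compound reaches a measurable value.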